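A few compounds are considered here, and "the series" means these few. Any claim that something is new, unique, unknown or untested is made for them only; others in the source may bear on it.

Working notes on the series.

Among the measured compounds shown here, compound 2 `CC(C)CNC(C)(C)CC(=O)N[C@@H]1CCc2ccccc2N(Cc2ccc(-c3ccccc3-c3nn[nH]n3)cc2)C1=O` gives 85 uM in a functional assay on cells (Pituitary gland cell) with growth hormone secretagogue receptor type 1 (Rattus norvegicus) as the target (on this read-out lower numbers stand for an effect already at smaller amounts and higher numbers for an effect only at larger amounts of compound), the higher of the two numbers so far; its neighbour compound 1 `CC(C)(CC(=O)N[C@@H]1CCc2ccccc2N(Cc2ccc(-c3ccccc3-c3nn[nH]n3)cc2)C1=O)NCCO` gives 30 uM. For the measured compounds named here, the only measured step, a 2.8-fold higher number from compound 1 to compound 2 (0.45 log units; beyond the scatter), replaced hydroxymethyl by isopropyl on a saturated chain carbon bound to the amine nitrogen and moved the number modestly upward, beyond the scatter.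

Compound 3 `CC(C)(CN)C(=O)N[C@@H]1CCc2ccccc2N(Cc2ccc(-c3ccccc3-c3nn[nH]n3)cc2)C1=O` is to be measured. It differs from compound 2 by 1-(aminomethyl)-1-methylethyl in place of 2-(isobutylamino)-2-methylpropyl on a carbonyl carbon: the isobutyl on the amine nitrogen is gone, the amine becomes primary, and the chain between amine and carbonyl is one carbon shorter. Going by the values given here, no measured step covers this change directly. Among the compounds with values here, the step from compound 1 to compound 2 shows that adding carbon on that chain carbon cost potency; the change to compound 3 removes carbon from the same region, so a step in the opposite direction is plausible, though the shortening of the chain has no precedent here.

For compound 3 the expectation is a 3.4-fold lower number from compound 2 to compound 3 (0.53 log units; beyond the scatter), giving an estimated 25 uM with a range from 6 uM to 100 uM.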

Compound 3, concentration for half-maximal effect: 3 uM
Beside the measured number, compound 3's estimate is 8.3-fold (0.92 log units) above it; the whole stated range lies above it.
By their numbers in this assay, from the lowest: compound 3; then compound 1; then compound 2.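

In this assay, among the compounds shown here, the group on this carbonyl carbon turns out to matter more than the only earlier step suggested: 1-(aminomethyl)-1-methylethyl in place of 2-(isobutylamino)-2-methylpropyl gives a 28-fold lower number from compound 2 to compound 3 (1.45 log units; beyond the scatter), a much larger change than a 2.8-fold higher number from compound 1 to compound 2 (0.45 log units; beyond the scatter). The same group in place of 2-((2-hydroxyethyl)amino)-2-methylpropyl gives a 10-fold lower number from compound 1 to compound 3 (1.00 log units; beyond the scatter), so the primary amine on the shorter chain stands clear of both substituted amines on the longer chain, and compound 3 holds the lowest number of the three, with both of its steps beyond the scatter. Nothing available explains the size of these steps.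

Compound 3 differs from its two neighbours in two ways at once, the missing substituent on the amine nitrogen and the shorter chain, so the compounds shown cannot assign the gain to either change alone. As far as these compounds go, a 2-amino-2-methylpropyl group, which keeps the longer chain with a primary amine, would separate the two, and whether an isobutyl on the amine nitrogen of the shorter chain keeps the low number also remains open.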